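From piperidin-1-yl to hydroxy on a side chain

The source may hold more compounds than are shown below. What is called first, only, known or untested is meant among the compounds shown, and "the series" means these compounds.

In a functional assay on LNCaP cells (Homo sapiens) for antiproliferative activity (on this read-out higher numbers stand for weaker inhibition and lower numbers for stronger inhibition), compound 1 `Cn1ncc(Cl)c1-c1cc(C(=O)N[C@@H]2CN[C@H](CC(O)CO)C[C@H]2c2ccc(F)c(F)c2)oc1Cl` gives 100 nM and compound 2 `CC(=O)NCC[C@@H]1C[C@@H](c2ccc(F)c(F)c2)[C@H](NC(=O)c2cc(-c3c(Cl)cnn3C)c(Cl)o2)CN1` gives 130 nM. Compound 3 `Cn1ncc(Cl)c1-c1cc(C(=O)N[C@@H]2CN[C@H](CCN3CCCCC3)C[C@H]2c2ccc(Cl)c(Cl)c2)oc1Cl` has the highest number of the three at 1780 nM, which makes it the weakest inhibitor so far. Compound 4 `Cn1ncc(Cl)c1-c1cc(C(=O)N[C@@H]2CN[C@H](CCO)C[C@H]2c2ccc(Cl)c(Cl)c2)oc1Cl` alters compound 3 in one place, at the end of a side chain: hydroxy in place of piperidin-1-yl on a saturated chain carbon, two bonds along the chain from a saturated ring carbon. Going by the values given here, no measured step makes this exact swap. Among the compounds with values here, the only measured step, a 1.3-fold higher number from compound 1 to compound 2 (0.11 log units; within the scatter), exchanges one chain end without piperidin-1-yl for another and stays within the scatter. That step shows that these two chain ends give similar numbers, but it says nothing directly about removing piperidin-1-yl. Compound 1 at 100 nM also lacks piperidin-1-yl, yet it differs from compound 3 in more than the chain, so the comparison is only a loose guide. A clearly lower number is therefore expected, with the change estimated as an 8.9-fold lower number from compound 3 to compound 4 (0.95 log units; beyond the scatter). The expected value for compound 4 is 200 nM, within an estimated range of 50 nM to 800 nM.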

Compound 4, half-maximal inhibitory concentration: 160 nM
Compound 4: middle estimate off by 1.3-fold (0.10 log units), on the high side; the measured number falls inside the stated range.
By their numbers in this assay, from the lowest: compounds 1, 2 and 4 (each within the scatter of the next); then compound 3.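

In this assay, going by these compounds alone, the step is large and lies beyond the scatter (an 11-fold lower number from compound 3 to compound 4 (1.05 log units; beyond the scatter)), giving the first direct evidence that the group at the end of this side chain can strongly change the read-out. The earlier step compared two chain ends without piperidin-1-yl and stayed within the scatter, so it could not show how far the numbers might move at this position. Here, with the rest of the molecule unchanged, 2-hydroxyethyl gives a far lower number than 2-(piperidin-1-yl)ethyl, but no available evidence explains the difference.

A single swap cannot separate the loss of piperidin-1-yl from the gain of hydroxy. Compounds ending in a methoxy group, a dimethylamino group or a carboxylic acid, or carrying a longer chain, would help show which feature tracks the read-out.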